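This account rests on a few compounds, and the source may have more. Where it says the series, first, only, none or still open, it means among the compounds named here.

Measured compounds:
compound 1 `CC(C)[C@@H](NC(=O)/C=C/c1ccncc1-c1ccc2ccccc2c1)C(=O)O` — "not determined" (no result reported) in a functional assay on HCT-116 cells (Homo sapiens) for inhibition, read by MTT assay, with a stated time of 72 h; on this read-out higher numbers stand for weaker inhibition of growth and lower numbers for stronger inhibition of growth
compound 2 `CNC(=O)/C=C/c1ccncc1-c1ccc2c(cnn2C)c1` — 3480 nM in this assay

Compound 1 stands without a number: in this assay it returned "not determined" (no result reported), so nothing can be said of where it sits relative to compound 2. Compound 2 is the only anchor for the series, and in this assay compound 2 gives 3480 nM. For the measured compounds named here, no step between measured compounds is available, so compound 2 and compound 1 are not compared here beyond noting that one carries a value and the other does not.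

Compound 3 `COC(=O)/C=C/c1ccncc1-c1ccc2ccccc2c1` is the next member to be measured. Its difference from compound 1 is the following: methoxy in place of (1-carboxy-2-methylpropyl)amino on a carbonyl carbon. Going by the values given here, with no measured step to draw on, the size of the change from compound 1 to compound 3 in this assay cannot be read from any pair in hand; the working assumption is that it stays within the scatter, with no direction favoured.

Among the compounds with values here, compound 3 is expected to fall near 3000 nM in this assay, within an estimated range of 700 nM to 13000 nM, resting on the single number that compound 2 gives, 3480 nM.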

Compound 3, concentration for 50% growth inhibition: 350 nM
The estimate for compound 3 lay 8.6-fold (0.93 log units) above the measured number, and the stated range ends above it.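

In this assay compound 3 gives 350 nM and compound 1 returned "not determined" (no result reported) so no step can be read between the two compounds. The compounds shown leave open how replacing (1-carboxy-2-methylpropyl)amino with methoxy on the carbonyl carbon affects growth inhibition. No supporting data bear on this result.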